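Replacing pyrrolidin-1-yl with morpholin-4-yl on a carbonyl carbon

A few compounds are considered here, and "the series" means these few. Any claim that something is new, unique, unknown or untested is made for them only; others in the source may bear on it.

- Compound 1 `CCCCCCCC/C=C\CCCCCCCC(=O)N1CCCC1` gives 3.8 ug/mL as its measured value
- Compound 2 `CCCCCCCCCCCCCCCCCC(=O)N[C@H](C)c1ccccc1` gives 161 ug/mL as its measured value

In a functional assay on U-251 cells (Homo sapiens) for antiproliferative activity, read by sulforhodamine B assay, with a stated time of 48 h (a lower number here means a stronger inhibitor of growth, a higher number a weaker inhibitor of growth), compound 1 holds the lower of the two numbers, so it is the stronger inhibitor of growth here, and compound 2 lies well above it, beyond the scatter. For the measured compounds named here, compound 2 differs from compound 1 in more than one place, so the pair offers no measured step for the swap considered next.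

Compound 3 `CCCCCCCC/C=C\CCCCCCCC(=O)N1CCOCC1` has not yet been measured. It keeps the core of compound 1 and changes in one place, on a carbonyl carbon, where morpholin-4-yl stands in place of pyrrolidin-1-yl: morpholin-4-yl in place of pyrrolidin-1-yl on a carbonyl carbon is the whole difference. Going by the values given here, with no measured example of this swap, the expectation rests only on compound 1 at 3.8 ug/mL and on the limited extent of the change. The expected change is a 2.4-fold higher number from compound 1 to compound 3 (0.37 log units; beyond the scatter) as a modest step towards weaker inhibition of growth, and this remains uncertain. For compound 3 the estimated value is 9 ug/mL with an expected range from 2.5 ug/mL to 35 ug/mL in this measurement.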

Compound 3, concentration for 50% growth inhibition: 2.8 ug/mL
Estimate against measurement, compound 3: 3.2-fold (0.51 log units) above; the range from low to high includes it.
By their numbers in this assay, from the lowest: compounds 3 and 1 (each within the scatter of the next); then compound 2.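

In this assay, for the compounds shown here, the swap gives a 1.4-fold lower number from compound 1 to compound 3 (0.13 log units; within the scatter), which is the first measured example of this change. On a carbonyl carbon whose other neighbour is a saturated chain carbon, a six-membered ring with an oxygen and one hydrogen-bond acceptor can therefore stand in place of the five-membered pyrrolidin-1-yl ring, and the two readings cannot be told apart from ordinary repeat variation. No measurement at hand offers any explanation of why these two groups read alike.

Going by these compounds alone, this single pair covers only two groups at this position, so it remains open whether others, such as piperidin-1-yl or an open-chain diethylamino group, would also read like compound 1 and compound 3. Going by these compounds, it also remains open whether the same swap would behave this way on another chain, such as a fully saturated chain in place of the one with a double bond, and compound 2 cannot settle this, as it differs from compound 1 in more than one place.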